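A few compounds are considered here, and "the series" means these few. Any claim that something is new, unique, unknown or untested is made for them only; others in the source may bear on it.

In a functional assay (muscle tissue) with Cavia porcellus as the target (on this read-out higher numbers stand for an effect only at larger amounts of compound and lower numbers for an effect already at smaller amounts), compound 3 (`COC(=O)C1=C(C)N=C(C)/C(=C(\O)OC)C1c1ccccc1C`) gives 6.03 nM and compound 2 (`CCc1ccccc1C1C(C(=O)OC)=C(C)N=C(C)/C1=C(\O)OC`) gives 6.46 nM, level with each other (a 1.1-fold lower number from compound 2 to compound 3 (0.03 log units; within the scatter)). Compound 1 (`COC(=O)C1=C(C)N=C(C)/C(=C(\O)OC)C1c1cccc(N)c1`) stands far from both at 2000 nM.

Compound 4 (`COC(=O)C1=C(C)N=C(C)/C(=C(\O)OC)C1c1cccc(F)c1`) has 3-fluorophenyl in place of 2-methylphenyl on a saturated ring carbon.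

The most relevant measured steps are those from compound 1, with 3-aminophenyl, the closest measured group to 3-fluorophenyl by name. Both are large: a 330-fold lower number from compound 1 to compound 3 (2.52 log units; beyond the scatter) and a 310-fold lower number from compound 1 to compound 2 (2.49 log units; beyond the scatter). Among the compounds with values here, the step between the other two compounds (a 1.1-fold lower number from compound 2 to compound 3 (0.03 log units; within the scatter)) shows only that a change from 2-ethylphenyl to 2-methylphenyl leaves the number within the scatter, and says little about the present change. Within the data shown here, no measured compound carries fluorine, so only part of the large steps is carried over. The expected change is a partial move toward a higher number, a 13-fold higher number from compound 3 to compound 4 (1.12 log units; beyond the scatter). For compound 4 the estimated value in this assay is 80 nM, with an expected range of 15 nM to 500 nM.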

Compound 4, half-maximal effective concentration: 20.9 nM
Beside the measured number, compound 4's estimate is 3.8-fold (0.58 log units) above it; measured number inside the range.
By their numbers in this assay, from the lowest: compounds 3 and 2 (each within the scatter of the next); then compound 4; then compound 1.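

In this assay, fluoro in place of amino on the same aromatic carbon is a large step (a 96-fold lower number from compound 1 to compound 4 (1.98 log units; beyond the scatter)), so among these compounds a substituent at that place on the phenyl does not by itself give a number as high as that of compound 1. The 3-fluorophenyl group stays much nearer the two 2-alkylphenyl groups, yet the steps to it remain beyond the scatter, modest in size (a 3.5-fold higher number from compound 3 to compound 4 (0.54 log units; beyond the scatter)) and (a 3.2-fold higher number from compound 2 to compound 4 (0.51 log units; beyond the scatter)). Nothing at hand accounts for the size of any of these steps.

Still open, going by these compounds, is whether 2-fluorophenyl or 3-methylphenyl would stand with compound 3 or with compound 4, which would separate the effect of the group from that of its place on the phenyl. Also open, on these data alone, is where 3-hydroxyphenyl or 3-methoxyphenyl would fall relative to compound 1 and compound 4.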